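The source may report more compounds than this note shows. Statements on the series, on what has been measured and on what is new or still open speak of the compounds shown alone.

Measured in a functional assay on HL-60 cells (Homo sapiens) for inhibition, read by MTT assay, with a stated time of 48 h, tested at 10 uM; a higher number here means more inhibition of growth at the concentration tested, a lower number less inhibition of growth:
compound 1 `Cc1oc2c([C@H]3CCN(C)C[C@H]3O)c(O)cc(O)c2c(=O)c1C(O)c1cccc(Cl)c1`: 22%
compound 2 `Cc1oc2c([C@H]3CCN(C)C[C@H]3O)c(O)cc(O)c2c(=O)c1C(O)c1ccccc1Br`: 52%
compound 3 `Cc1oc2c([C@H]3CCN(C)C[C@H]3O)c(O)cc(O)c2c(=O)c1C(O)c1c(F)cccc1Cl`: 49%

Compound 3 belongs to the upper pair of these numbers, with a number 3 percentage points lower from compound 2 to compound 3 (within the scatter) and a number 27 percentage points higher from compound 1 to compound 3 (beyond the scatter). Compound 4 `COc1ccc(C(O)c2c(C)oc3c([C@H]4CCN(C)C[C@H]4O)c(O)cc(O)c3c2=O)cc1Br` alters only the aryl group: 3-bromo-4-methoxyphenyl in place of 2-chloro-6-fluorophenyl on a saturated chain carbon bound to an aromatic carbon and an oxygen on a saturated carbon. Among the measured compounds shown here, no measured step makes this exact exchange. The nearest evidence is a number 30 percentage points higher from compound 1 to compound 2 (beyond the scatter), together with the step from compound 1 to compound 3 already given. Both start from the 3-chlorophenyl of compound 1, the measured group whose name comes closest to 3-bromo-4-methoxyphenyl. On these data alone, a partial return towards compound 1 therefore seems likely, though the methoxy group is untested. The expected change in this assay is a number 18 percentage points lower from compound 3 to compound 4 (beyond the scatter). For compound 4 the estimated value is 31%, within an expected range of 12% to 52%.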

Compound 4, percent growth inhibition at one concentration: 23%
The estimate for compound 4 lay 8 percentage points above the measured number; measured number inside the range.
By their numbers in this assay, from the lowest: compounds 1 and 4 (each within the scatter of the next); then compounds 3 and 2 (each within the scatter of the next).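

In this assay, 3-bromo-4-methoxyphenyl on this saturated chain carbon gives a number 26 percentage points lower from compound 3 to compound 4 (beyond the scatter) and a number 29 percentage points lower from compound 2 to compound 4 (beyond the scatter), with a number 1 percentage points higher from compound 1 to compound 4 (within the scatter) as the third step. Among these four compounds, 2-bromophenyl and 2-chloro-6-fluorophenyl form the upper pair, while 3-chlorophenyl and 3-bromo-4-methoxyphenyl form the lower, so bromine in the name does not place a compound in the upper pair. No measurement available here explains this split.

The compounds shown leave open how 4-methoxyphenyl without the bromine would read in this assay. They also leave open whether an aminophenyl or a carboxyphenyl group would fall with either pair.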